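Chloro to trifluoromethyl on the benzyl group, working notes

This account rests on a few compounds, and the source may have more. Where it says the series, first, only, none or still open, it means among the compounds named here.

In a functional assay on MCF7 cells (Homo sapiens) for antiproliferative activity, read by sulforhodamine B assay, with a stated time of 48 h (on this read-out higher numbers stand for weaker inhibition of growth and lower numbers for stronger inhibition of growth), compound 2 `COc1ccc(-c2nn(-c3ccccc3)cc2C(=O)NCc2cn(Cc3ccc(Cl)cc3)nn2)cc1` gives 2900 nM. Compound 1 `O=C(NCc1cn(Cc2ccc(C(F)(F)F)cc2)nn1)c1cn(-c2ccccc2)nc1-c1ccc(Cl)cc1`, which differs from it in two places, gives 4900 nM in this assay; the two numbers in hand lie within the scatter of each other, so neither stands apart. Compound 3 `COc1ccc(-c2nn(-c3ccccc3)cc2C(=O)NCc2cn(Cc3ccc(C(F)(F)F)cc3)nn2)cc1` is not yet measured; it carries trifluoromethyl in place of chloro on an aromatic carbon. Within the data shown here, no single-change step between measured compounds is available, and the step expected here is a 1.2-fold higher number from compound 2 to compound 3 (0.08 log units; within the scatter), none beyond the scatter. Compound 3 is therefore expected to give 3500 nM in this assay, with a range from 1200 nM to 10000 nM.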

Compound 3, concentration for 50% growth inhibition: > 100000 nM
Compound 3 gave a limit, no number (the forecaster's own chance of this, stated with the estimate: 5%); at least 28-fold (1.45 log units) between middle value and limit.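

In this assay, the change from 4-chlorobenzyl to 4-(trifluoromethyl)benzyl is not neutral when methoxy is kept on the other aromatic ring, giving an at least 34-fold higher number from compound 2 to compound 3 (1.53 log units; beyond the scatter) across this single change. With 4-(trifluoromethyl)benzyl kept, methoxy in place of chloro also gives a large step (an at least 20-fold higher number from compound 1 to compound 3 (1.30 log units; beyond the scatter)), so among these three compounds the loss appears only where methoxy and trifluoromethyl occur together. Compound 3 stands at a limit of the assay, not at a number: the limit of > 100000 nM in this assay, at which 1 of the 3 values shown sits.

Whether the two changes depend on each other remains open, as no compound shown pairs chloro on both aromatic rings. Also open, from the compounds shown here alone, is how an amine or a carboxylic acid on this aromatic carbon would read out.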